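A few compounds are considered here, and "the series" means these few. Any claim that something is new, unique, unknown or untested is made for them only; others in the source may bear on it.

Compound 1 `Cn1c(=O)c2c(nc(Sc3ccccc3)n2C)n(C)c1=O` is one of two compounds with a result in an assay on isolated protein for inhibition of Amine oxidase [flavin-containing] B (Homo sapiens), read by fluorescence; on this read-out higher numbers stand for weaker inhibition and lower numbers for stronger inhibition. In this assay compound 1 gives 33200 nM, the highest of the two numbers available, and so the weaker of the pair. Its nearest neighbour, compound 2 `Cn1c(=O)c2c(nc(SCc3ccc(Cl)cc3)n2C)n(C)c1=O`, gives 192 nM in this assay, a gap well beyond the scatter, but the two structures differ in more than one place, so no single step can be read from them.

Compound 3 `Cn1c(=O)c2c(nc(SC3CCCCC3)n2C)n(C)c1=O` has not yet been measured in this assay. It differs from compound 1 in one place: cyclohexyl in place of phenyl on a sulfur. Among the measured compounds shown here, because compound 1 stands at 33200 nM and no measured pair shows this particular exchange, the direction of the change is uncertain, and the step from compound 1 to compound 3 is expected to be small, most likely within the scatter, a 1.3-fold lower number from compound 1 to compound 3 (0.12 log units; within the scatter). Compound 3 is accordingly estimated to give 25000 nM in this assay, with a range from 6000 nM to 90000 nM.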

Compound 3, half-maximal inhibitory concentration: 13100 nM
Beside the measured number, compound 3's estimate is 1.9-fold (0.28 log units) above it; the measured number falls inside the stated range.
By their numbers in this assay, from the lowest: compound 2; then compound 3; then compound 1.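

Among the compounds shown here, the exchange of phenyl for cyclohexyl on a sulfur gives the first step that can be read in this assay: a 2.5-fold lower number from compound 1 to compound 3 (0.40 log units; beyond the scatter), modest in size but beyond the scatter. At this position, on a sulfur whose other neighbour is an aromatic carbon, the ring therefore need not be aromatic for inhibition to persist, and here the non-aromatic ring of the same six carbons gives the lower number. No measurement offers an explanation for this step, so the result stands as an observation about this single exchange.

The compounds shown leave open whether the number on this sulfur depends on ring size, as a cyclopentyl or cycloheptyl group would test, or on the presence of a ring at all, as an open chain such as n-hexyl would test. They also leave open how a ring carrying an amine, such as a piperidine, or a cyclohexyl ring bearing a carboxylic acid would fare at this position, and whether the step seen here would recur with other groups on the shared core.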